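This account rests on a few compounds, and the source may have more. Where it says the series, first, only, none or still open, it means among the compounds named here.

Values in a functional assay on K562 cells (Homo sapiens) for cytotoxicity, read by MTT assay, with a stated time of 48 h; a lower number here means a stronger inhibitor, a higher number a weaker inhibitor:
compound 1 `CCCCCCCCNc1n[n+]([O-])c2ccccc2[n+]1[O-]`: 4700 nM
compound 2 `[O-][n+]1nc(NCc2ccccc2)[n+]([O-])c2ccccc21`: 1900 nM
compound 3 `O=[N+]([O-])c1ccc(CNc2n[n+]([O-])c3ccccc3[n+]2[O-])cc1`: 3100 nM

Compound 2 carries the lowest number of the three; the gap to compound 3, a 1.6-fold higher number from compound 2 to compound 3 (0.21 log units; within the scatter), lies within the scatter, while the gap to compound 1, given by a 2.5-fold lower number from compound 1 to compound 2 (0.39 log units; beyond the scatter), lies beyond it. Compound 4 `CCNc1n[n+]([O-])c2ccccc2[n+]1[O-]` differs from compound 2 by methyl in place of phenyl on a saturated chain carbon bound to a nitrogen on an aromatic ring. Going by the values given here, the only measured step that bears on this is a 2.5-fold lower number from compound 1 to compound 2 (0.39 log units; beyond the scatter), where a chain gave way to phenyl and the number fell; here phenyl gives way to a chain again, though a far shorter one. A modest rise in the number is therefore expected, roughly a 2.0-fold higher number from compound 2 to compound 4 (0.30 log units; within the scatter). Compound 4 is estimated at 3800 nM, with a range of 1500 nM to 9500 nM.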

Compound 4, half-maximal inhibitory concentration: 4500 nM
Estimate against measurement, compound 4: 1.2-fold (0.07 log units) below, within the range that was stated.
By their numbers in this assay, from the lowest: compounds 2, 3, 4 and 1 (each within the scatter of the next, the first and the last beyond it).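

In this assay, methyl in place of phenyl on a saturated chain carbon bound to a nitrogen on an aromatic ring gives a 2.4-fold higher number from compound 2 to compound 4 (0.37 log units; beyond the scatter) and so a rise of the same order as leaving phenyl for heptyl. The two chains do not separate: hydrogen in place of hexyl gives a 1.0-fold lower number from compound 1 to compound 4 (0.02 log units; within the scatter) and, across this span, chain length has no readable effect. Nothing at hand explains why phenyl gives the lower number.

Still open, on these data alone, is whether a saturated ring such as cyclohexyl would match phenyl at this place, which would tell the ring from its aromatic character. An amine or a carboxylic acid at the chain end also remains untested in the compounds shown here.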